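The source may hold more compounds than are shown below. What is called first, only, known or untested is meant among the compounds shown, and "the series" means these compounds.

Measured compounds:
- compound 1, `Cc1cc2c(cc1C)C(Cl)=C(/C=N/NC(=O)c1ccccc1)CCC2`
- compound 2, `Cc1ccc(C(=O)N/N=C/C2=C(Cl)c3cc(C)c(C)cc3CCC2)cc1`
- compound 3, `COc1cccc(C(=O)N/N=C/C2=C(Cl)c3cc(C)c(C)cc3CCC2)c1C`

In a functional assay on HeLa cells (Homo sapiens) for inhibition, read by sulforhodamine B assay, with a stated time of 48 h (a lower number here means a stronger inhibitor of growth, a higher number a weaker inhibitor of growth), compound 1 gives only a limit, > 100000 nM. Compound 2 likewise gives only a limit in this assay, > 100000 nM. Among the compounds with values here, compound 3 gives the single real number in the set, 300 nM. Within the data shown here, compound 3 thus stands alone as the one compound with a readable value; the other two sit at the limit of > 100000 nM in this assay, at which 2 of the 3 values shown sit.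

The step to compound 4, `Cc1cc2c(cc1C)C(Cl)=C(/C=N/NC(=O)c1cccc(Cl)c1)CCC2`, is 3-chlorophenyl in place of 3-methoxy-2-methylphenyl on a carbonyl carbon. Among the measured compounds shown here, two measured steps touch the same carbonyl-bound aryl group: an at least 330-fold lower number from compound 1 to compound 3 (2.52 log units; beyond the scatter) and an at least 330-fold lower number from compound 2 to compound 3 (2.52 log units; beyond the scatter), both large and both leading to compound 3. The step that the two limits leave unreadable from compound 1 to compound 2 cannot be read because both ends are limits. So the data show that a plain phenyl or 4-methylphenyl at this position gives no measurable inhibition, while the 3-methoxy-2-methylphenyl gives a clear number. A 3-chlorophenyl is neither; in this assay a step of a 33-fold higher number from compound 3 to compound 4 (1.52 log units; beyond the scatter) is expected, toward a weaker number, with a real chance that only a limit is returned. Compound 4 is estimated at 10000 nM, in the range 1000 nM to 100000 nM.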

Compound 4, concentration for 50% growth inhibition: 770 nM
The estimate for compound 4 lay 13-fold (1.11 log units) above the measured number; measured number outside the range, below it.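

Measurable growth inhibition at this position does not depend on the 3-methoxy-2-methylphenyl group: in this assay there is a 2.6-fold higher number from compound 3 to compound 4 (0.41 log units; beyond the scatter), a modest step that still returns a real number. Set against the plain phenyl, the 3-chlorophenyl gives an at least 120-fold lower number from compound 1 to compound 4 (2.11 log units; beyond the scatter), and 3-chlorophenyl in place of 4-methylphenyl gives an at least 120-fold lower number from compound 2 to compound 4 (2.11 log units; beyond the scatter), so the substituent matters and a methyl-bearing ring alone does not secure a number. Compound 1 and compound 2 are limits, so these two steps are minimum sizes: the limit of > 100000 nM in this assay, at which 2 of the 4 values shown sit.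

Whether the chloro must sit as it does in the 3-chlorophenyl remains open, as no other chlorophenyl is shown. Also open, going by these compounds, is how an amine or a carboxylic acid on this aryl ring would read in this assay.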